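The source may report more compounds than this note shows. Statements on the series, on what has been measured and on what is new or still open speak of the compounds shown alone.

In a functional assay (QGY7701 cells, Homo sapiens) for inhibition, read by MTT assay, with a stated time of 48 h (a lower number here means a stronger inhibitor, a higher number a weaker inhibitor), compound 1 `COc1ccc2c(=O)c(/C=C/C(=O)Nc3cccc(C)c3)coc2c1` gives > 100000 nM, which is a limit of the assay rather than a number. Compound 2 `COc1ccc2c(=O)c(/C=C/C(=O)Nc3cccc(Cl)c3)coc2c1` also returns a limit, > 100000 nM. Compound 3 `COc1cccc(NC(=O)/C=C/c2coc3cc(OC)ccc3c2=O)c1` gives 39100 nM. The steps of an at least 2.5-fold lower number from compound 1 to compound 3 (0.40 log units; beyond the scatter) and an at least 2.5-fold lower number from compound 2 to compound 3 (0.40 log units; beyond the scatter) are both beyond the scatter, while the step that the two limits leave unreadable from compound 1 to compound 2 cannot be read. Compound 4 `COc1ccc2c(=O)c(/C=C/C(=O)NCc3ccccc3F)coc2c1` differs from compound 1 by 2-fluorobenzyl in place of 3-methylphenyl on an amide-type nitrogen. Going by the values given here, none of the measured steps bears on this exchange, as each of them swapped one substituent on the aromatic ring, whereas here the whole group on the amide-type nitrogen is replaced. Given (the limit of > 100000 nM in this assay, at which 2 of the 3 values shown sit), the step of an at least 1.2-fold lower number from compound 1 to compound 4 (0.09 log units; that floor lies within the scatter) is expected to be small. Compound 4 is estimated at 80000 nM, with a range from 25000 nM to 300000 nM.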

Compound 4, half-maximal inhibitory concentration: 34000 nM
For compound 4 the middle estimate is 2.4-fold (0.37 log units) above the measured one; the range from low to high includes it.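

Exchanging the whole group on the amide-type nitrogen gives a readable value where the 3-methylphenyl and 3-chlorophenyl groups gave only limits, with an at least 2.9-fold lower number from compound 1 to compound 4 (0.46 log units; beyond the scatter) and an at least 2.9-fold lower number from compound 2 to compound 4 (0.46 log units; beyond the scatter). Both steps are floors, not sizes: the limit of > 100000 nM in this assay, at which 2 of the 4 values shown sit.

The 2-fluorobenzyl group and the 3-methoxyphenyl group cannot be told apart at this position, with a 1.2-fold lower number from compound 3 to compound 4 (0.06 log units; within the scatter).

The compounds shown leave open whether the benzyl part or the fluorine accounts for the change. On these data alone, how a plain benzyl or a 2-phenylethyl group would read on this nitrogen also stays open.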